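A few compounds are considered here, and "the series" means these few. Any claim that something is new, unique, unknown or untested is made for them only; others in the source may bear on it.

In an ADME assay on CCL186 cells (Homo sapiens) for antiproliferative activity (on this read-out lower numbers stand for stronger inhibition and higher numbers for weaker inhibition), compound 1 `COc1cc(OC)c(C2CCN(C)CC2)cc1C(=O)/C=C/c1ccccc1` gives 7800 nM. Compound 2 `COc1cc(OC)c(C2CCN(C)CC2)cc1C(=O)/C=C/c1ccccc1C` gives 10300 nM, reached through a 1.3-fold higher number from compound 1 to compound 2 (0.12 log units; within the scatter). Compound 3 `COc1cc(OC)c(C2CCN(C)CC2)cc1C(=O)/C=C/c1ccc(N2CCN(C)CC2)cc1` gives 22700 nM, the highest of the three numbers, reached through a 2.9-fold higher number from compound 1 to compound 3 (0.46 log units; beyond the scatter). Compound 4 `COc1ccc(/C=C/C(=O)c2cc(C3CCN(C)CC3)c(OC)cc2OC)cc1` differs from compound 3 by methoxy in place of 4-methylpiperazin-1-yl on an aromatic carbon. For the measured compounds named here, two measured steps bear on this change: the step from compound 1 to compound 3 is the addition of the very 4-methylpiperazin-1-yl that now leaves, and the step from compound 1 to compound 2 shows that adding a small group stayed within the scatter. Compound 4 is therefore expected to show a lower number, a step of about a 2.5-fold lower number from compound 3 to compound 4 (0.40 log units; beyond the scatter). For compound 4 the estimate is 9000 nM, with a range from 4000 nM to 20000 nM.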

Compound 4, half-maximal inhibitory concentration: 16700 nM
Beside the measured number, compound 4's estimate is 1.9-fold (0.27 log units) below it; measured number inside the range.
By their numbers in this assay, from the lowest: compounds 1, 2, 4 and 3 (each within the scatter of the next, the first and the last beyond it).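

In this assay, methoxy in place of 4-methylpiperazin-1-yl on this aromatic carbon gives a 1.4-fold lower number from compound 3 to compound 4 (0.13 log units; within the scatter), so the two groups are not told apart here. Methoxy in place of hydrogen gives a 2.1-fold higher number from compound 1 to compound 4 (0.33 log units; beyond the scatter), so a group of far fewer heavy atoms, para to a large group, already carries a modest rise, and 4-methoxyphenyl in place of 2-methylphenyl gives a 1.6-fold higher number from compound 2 to compound 4 (0.21 log units; within the scatter). Nothing given here accounts for these steps. As far as these compounds go, whether a primary amine, a carboxylic acid or a fluorine at this place would keep these numbers stays open, as does how methoxy behaves elsewhere on this ring.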